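From phenyl to 4-methylbenzyl at the assay limit

A few compounds are considered here, and "the series" means these few. Any claim that something is new, unique, unknown or untested is made for them only; others in the source may bear on it.

In a functional assay on HeLa cells (Homo sapiens) for cytotoxicity, read by MTT assay, with a stated time of 48 h (a higher number here means a weaker inhibitor, a lower number a stronger inhibitor), compound 1 `CCOC(=O)[C@]1(C(=O)Nc2ccccc2)C[C@@H]1c1cc(OC)c(OC)c(OC)c1` gives > 100000 nM as a limit of the assay and not a number. Compound 2 `COc1cc([C@H]2C[C@]2(CO)C(=O)Nc2ccccc2)cc(OC)c1OC` gives > 100000 nM as a limit too. Within the data shown here, their one measured change, hydroxymethyl in place of ethoxycarbonyl on a saturated ring carbon, is a step that the two limits leave unreadable from compound 1 to compound 2 and so offers no size to borrow. Among the measured compounds shown here, the series so far shows only the limit of > 100000 nM in this assay, at which 2 of the 2 values shown sit, and no number.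

Compound 3 `CCOC(=O)[C@]1(C(=O)NCc2ccc(C)cc2)C[C@@H]1c1cc(OC)c(OC)c(OC)c1` keeps the core of compound 1 and carries 4-methylbenzyl in place of phenyl on an amide-type nitrogen. For the measured compounds named here, the difference is 4-methylbenzyl in place of phenyl on an amide-type nitrogen and no measured step touches that place. The expectation therefore rests on compound 1 with its limit of > 100000 nM as the only starting point. No clear move is expected, and the estimated step is a number no higher from compound 1 to compound 3 (the limit leaves the size open) in this assay with another limit quite likely. For compound 3 the estimate is 100000 nM with an expected range from 30000 nM to 200000 nM in this reading.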

Compound 3, half-maximal inhibitory concentration: > 100000 nM
Compound 3: only a limit was reported; the forecaster's own chance of this, stated with the estimate: 70%; the middle value lies on the limit itself.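

In this assay compound 3 gives > 100000 nM, a limit of the assay and not a number, and its step from compound 1 cannot be read. The compounds shown leave open which change to the shared core, if any, would give a measurable value: the limit of > 100000 nM in this assay, at which 3 of the 3 values shown sit.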